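The compounds below may be only part of what the source reports. "The series", "measured", "known", "first", "only" and "open" are said of these compounds alone.

Of the compounds shown here, three built on one shared core have been tested in a functional assay on SK-N-SH cells (Homo sapiens) for inhibition, read by MTT assay, with a stated time of 72 h; on this read-out higher numbers stand for weaker inhibition and lower numbers for stronger inhibition. Compound 1 `CN1CCN(C(=S)SCCCOc2ccc(C(=O)/C=C/c3cc(F)cc(F)c3)cc2)CC1` gives 13200 nM, compound 2 `O=C(/C=C/c1cccnc1)c1ccc(OCCCSC(=S)N2CCCC2)cc1` gives 24500 nM, and compound 3 `COc1cc(/C=C/C(=O)c2ccc(OCCSC(=S)N3CCN(C)CC3)cc2)cc(OC)c1OC` gives 2460 nM. Compound 2 thus shows the highest number of the three: its gap to compound 1 lies within the scatter, while compound 3 sits far lower, beyond the scatter. Compound 4 `O=C(/C=C/c1cc(F)cc(F)c1)c1ccc(OCCCSC(=S)N2CCCC2)cc1` has not yet been measured. It differs from compound 2 in one place: 3,5-difluorophenyl in place of pyridin-3-yl on a double-bonded chain carbon bound to a double-bonded chain carbon. Going by the values given here, no two measured compounds differ in exactly this way, so the size of this step is uncertain. Compound 1 carries the same 3,5-difluorophenyl group and gives 13200 nM, so compound 4 is expected to shift towards stronger inhibition by a step of a 1.9-fold lower number from compound 2 to compound 4 (0.28 log units; within the scatter). Compound 4 is estimated at 13000 nM, with a likely range from 5000 nM to 35000 nM.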

Compound 4, half-maximal inhibitory concentration: 36100 nM
Compound 4: middle estimate off by 2.8-fold (0.44 log units), on the low side, outside the stated range (above it).
By their numbers in this assay, from the lowest: compound 3; then compounds 1, 2 and 4 (each within the scatter of the next, the first and the last beyond it).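

In this assay the change from pyridin-3-yl to 3,5-difluorophenyl gives a 1.5-fold higher number from compound 2 to compound 4 (0.17 log units; within the scatter) and so leaves no readable difference between these two groups at this position. Pyrrolidin-1-yl in place of 4-methylpiperazin-1-yl on a thiocarbonyl carbon gives a 2.7-fold higher number from compound 1 to compound 4 (0.44 log units; beyond the scatter) and shows that this second place has a modest but readable effect. Nothing available explains either result. Open, as far as these compounds go, is whether an unsubstituted phenyl on the double-bonded chain carbon would also match these two groups. Also open, from the compounds shown here alone, is how a morpholin-4-yl on the thiocarbonyl carbon would compare with pyrrolidin-1-yl and 4-methylpiperazin-1-yl.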